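A Bromine-Bearing Ring Replaces the Methyl-Bearing Ring

The source may hold more compounds than are shown below. What is called first, only, known or untested is meant among the compounds shown, and "the series" means these compounds.

In an ADME assay on Vero cells (Chlorocebus sabaeus) for cytotoxicity, read by MTT assay, with a stated time of 72 h (a higher number here means that more compound is needed for the effect, a lower number that less compound is needed), compound 1 (`Cc1cccc(C(=O)Nc2nc(-c3ccccn3)cs2)c1`) gives 4100 nM and stands lowest of the two measured numbers, with compound 2 (`O=C(Nc1nc(-c2ccccn2)cs1)c1cccc(OCc2ccccc2)c1`) higher at 14400 nM so far. Compound 3 (`O=C(Nc1nc(-c2ccccn2)cs1)c1ccccc1Br`) is unmeasured and carries 2-bromophenyl in place of 3-methylphenyl on a carbonyl carbon. Among the compounds with values here, the one measured step (a 3.5-fold higher number from compound 1 to compound 2 (0.55 log units; beyond the scatter)) puts benzyloxy in place of methyl on an aromatic carbon, so it bears only loosely and is modest. Only a small upward step, perhaps none beyond the scatter, is therefore expected in this assay (a 1.3-fold higher number from compound 1 to compound 3 (0.13 log units; within the scatter)). Compound 3 is estimated at 5500 nM with an expected range of 2000 nM to 15000 nM for its value.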

Compound 3, half-maximal effective concentration: 3500 nM
Beside the measured number, compound 3's estimate is 1.6-fold (0.20 log units) above it, within the range that was stated.
By their numbers in this assay, from the lowest: compounds 3 and 1 (each within the scatter of the next); then compound 2.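

Putting 2-bromophenyl in place of 3-methylphenyl on a carbonyl carbon gives a 1.2-fold lower number from compound 1 to compound 3 (0.07 log units; within the scatter) in this assay, so the two compounds cannot be told apart here. Compound 2 showed a step beyond the scatter from a change on the ring, whereas compound 3 shows that the whole ring group can be exchanged, with bromine entering and methyl leaving, without such a step. From the compounds shown here alone, whether an amine or a carboxylic acid on this ring would also stay within the scatter remains open. Nothing measured here explains why compound 1 and compound 3 read alike.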